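Chloro for trifluoromethyl beside the cyclopropylmethoxy ether

A few compounds are considered here, and "the series" means these few. Any claim that something is new, unique, unknown or untested is made for them only; others in the source may bear on it.

Compound 1 `O=C(O)Cn1nc(Cc2nc3cc(Cl)c(OCC(F)F)cc3[nH]2)c2ccccc2c1=O` gives 15 nM in a functional assay on CHO cells for antagonist activity at sphingosine 1-phosphate receptor 2 (Homo sapiens), read by GTPgammaS binding; on this read-out lower numbers stand for stronger inhibition and higher numbers for weaker inhibition. Going by the values given here, compound 2 `CCOc1cc2[nH]c(Cc3nn(CC(=O)O)c(=O)c4ccccc34)nc2cc1Cl` gives 109 nM in this assay; the only one-place step among the measured compounds is a 7.3-fold higher number from compound 1 to compound 2 (0.86 log units; beyond the scatter), which touches the ether chain alone. Compound 3 `O=C(O)Cn1nc(Cc2nc3cc(C(F)(F)F)c(OCC4CC4)cc3[nH]2)c2ccccc2c1=O` gives 67 nM in this assay, the second highest of the three numbers: its gap to compound 2 lies within the scatter, while its gap to compound 1 lies beyond it.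

Compound 4 `O=C(O)Cn1nc(Cc2nc3cc(Cl)c(OCC4CC4)cc3[nH]2)c2ccccc2c1=O` differs from compound 3 by chloro in place of trifluoromethyl on an aromatic carbon. Among the compounds with values here, no measured step bears directly on this change, since a 7.3-fold higher number from compound 1 to compound 2 (0.86 log units; beyond the scatter) concerns the ether substituent and not the aromatic halogen or trifluoromethyl group. What the set does show is that chloro on this ring is compatible with either end of the range: compound 1 gives 15 nM, compound 2 gives 109 nM, and compound 3 with trifluoromethyl sits between them. On that basis no step beyond the scatter is expected for compound 4 in this assay. The estimate for compound 4 is 40 nM, with a range from 12 nM to 130 nM. The expected step is a 1.7-fold lower number from compound 3 to compound 4 (0.22 log units; within the scatter), a shift that would not exceed the usual scatter.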

Compound 4, half-maximal inhibitory concentration in the sphingosine 1-phosphate receptor 2 assay: 25 nM
Beside the measured number, compound 4's estimate is 1.6-fold (0.20 log units) above it, and the stated range covers the measured number.
By their numbers in the sphingosine 1-phosphate receptor 2 assay, from the lowest: compounds 1 and 4 (each within the scatter of the next); then compounds 3 and 2 (each within the scatter of the next).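

Going by these compounds alone, the first direct reading of this position in the sphingosine 1-phosphate receptor 2 assay is a 2.7-fold lower number from compound 3 to compound 4 (0.43 log units; beyond the scatter), for chloro in place of trifluoromethyl on the aromatic carbon ortho to a cyclopropylmethoxy group. With chloro held fixed, the ether chain can now be read twice in the sphingosine 1-phosphate receptor 2 assay: a 4.4-fold lower number from compound 2 to compound 4 (0.64 log units; beyond the scatter) for cyclopropyl in place of methyl, and a 1.7-fold higher number from compound 1 to compound 4 (0.22 log units; within the scatter) for cyclopropyl in place of difluoromethyl, which leaves these two chains not told apart. The same change at the aromatic carbon also shifts the compound in a physicochemical assay for lipophilicity, at pH 7.4 (a higher number here means a more lipophilic compound, a lower number a more polar compound), with compound 4 the more polar of the pair: the measured distribution coefficient of compound 3, 2.79, and of compound 4, 2.21, a number 0.58 log units lower (beyond the scatter) In the physicochemical assay compound 3 gives 2.79 and compound 4 gives 2.21.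

One pair cannot show whether the lower number in the sphingosine 1-phosphate receptor 2 assay follows the drop in lipophilicity or belongs to chloro itself. Also open, as far as these compounds go, is how a nitrile or bromo on this aromatic carbon would read in the sphingosine 1-phosphate receptor 2 assay, and whether the step from trifluoromethyl to chloro holds with an ether chain other than cyclopropylmethoxy.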